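Extending the Amide Methyl of Compound 1 by One Methyl

The source may hold more compounds than are shown below. What is called first, only, known or untested is meant among the compounds shown, and "the series" means these compounds.

Compound 1, with structure `CC[C@@H]1C(=O)N(C)c2cnc(-n3ccc4cc(C(=O)NC)ccc43)nc2N1C1CCCC1`, is the lower of the two numbers recorded in an assay for inhibition of serine/threonine-protein kinase PLK2 (Homo sapiens), read by FRET and Z'-LYTE, with a stated time of 1 h; a lower number here means a stronger inhibitor, a higher number a weaker inhibitor: in this measurement compound 1 gives 8.6 nM. The other measured compound, compound 2 with structure `CCC1C(=O)N(C)c2cnc(Nc3ccc(S(=O)(=O)NCCCO)cc3)nc2N1c1ccn(C)n1`, differs from it in several places at once; in this assay compound 2 gives 192 nM, a higher number that lies beyond the usual scatter, so compound 1 is the stronger inhibitor of the two.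

The next compound, compound 3 with structure `CCNC(=O)c1ccc2c(ccn2-c2ncc3c(n2)N(C2CCCC2)[C@H](CC)C(=O)N3C)c1`, is not yet measured. It differs from compound 1 in one place: methyl in place of hydrogen on a saturated chain carbon bound to an amide-type nitrogen. Going by the values given here, no pair of measured compounds shows this change, so its effect has to be estimated from the change alone. Turning methylcarbamoyl into ethylcarbamoyl is a small alteration, and the expectation is a small step in this assay, most likely within the scatter in either direction. For compound 3, the expected value in this assay is 10 nM, with a range from 4 nM to 25 nM. The expected step from compound 1 to compound 3 is a 1.2-fold higher number from compound 1 to compound 3 (0.07 log units; within the scatter).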

Compound 3, half-maximal inhibitory concentration: 4.88 nM
Compound 3: the middle estimate sits 2.0-fold (0.31 log units) above what was measured; measured number inside the range.
By their numbers in this assay, from the lowest: compounds 3 and 1 (each within the scatter of the next); then compound 2.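

Going from methylcarbamoyl to ethylcarbamoyl gives, in this assay, a 1.8-fold lower number from compound 1 to compound 3 (0.25 log units; within the scatter), which makes this the first comparison in the series where a single place on the molecule changes. The result shows that this position, a saturated chain carbon bound to an amide-type nitrogen, can carry one added methyl with no change in inhibition that stands clear of the usual scatter, so compound 1 and compound 3 cannot be ranked against each other. The earlier comparison of compound 1 with compound 2 could not show this, as those two differ in several places at once, and no separate measurement is available to explain the new result.

Still open, going by these compounds, is how far this tolerance extends: a longer chain such as propyl, a ring such as cyclopropyl, or a chain ending in an amine or a carboxylic acid might or might not stay within the scatter of compound 1. A single pair also leaves open whether the same added methyl would behave alike on a different core.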